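The source may report more compounds than this note shows. Statements on the series, on what has been measured and on what is new or still open speak of the compounds shown alone.

Measured so far in the series:

- compound 1, `O=C(O)Cc1sc(Cc2ccccc2)nc1-c1ccc(Cl)cc1`: 50%
- compound 2, `O=C(O)Cc1sc(C(c2ccc(F)cc2)c2ccc(F)cc2)nc1-c1ccnc(N2CCC2)c1`: 80%
- compound 3, `O=C(O)Cc1sc(C(c2ccccc2)c2ccccc2)nc1-c1ccc(C(F)(F)F)cc1`: 80%

In an in vitro functional assay on HEK285-7 cells for antagonist activity at prostaglandin D2 receptor 2 (Homo sapiens), read by BRET and beta-arrestin recruitment (a lower number here means a smaller maximal response, a higher number a larger maximal response), compound 2 gives 80%. Compound 3 gives 80% in this assay, level with compound 2 at the digits shown and within the scatter; these two are together the highest of the three numbers. Compound 1 gives 50% in this assay, a lower number than compound 2 and beyond the scatter, but compound 1 differs from compound 2 in several places at once, so no single change can be read from that gap.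

The next compound is compound 4, `COc1cc(-c2nc(C(c3ccc(F)cc3)c3ccc(F)cc3)sc2CC(=O)O)ccn1`. It differs from compound 2 in one place:

methoxy in place of azetidin-1-yl on an aromatic carbon

Among the measured compounds shown here, no pair of measured compounds isolates this change, so there is no measured step to lean on. Both groups carry one hydrogen-bond acceptor and neither carries a charge, and the rest of the structure is unchanged. The expectation is therefore a small step in this assay, most likely downward if any, and quite possibly none beyond the scatter. Compound 4 is expected to give 75% in this assay, with a range from 55% to 90%. The step that this estimate implies is a number 5 percentage points lower from compound 2 to compound 4 (within the scatter), which is expected to stay inside the usual scatter.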

Compound 4, largest response reached (reported as efficacy), in percent of the reference or control that the assay uses: 60%
The estimate for compound 4 lay 15 percentage points above the measured number, within the range that was stated.
By their numbers in this assay, from the lowest: compounds 1 and 4 (each within the scatter of the next); then compounds 2 and 3 (each within the scatter of the next).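

In this assay, among the compounds shown here, methoxy in place of azetidin-1-yl gives a number 20 percentage points lower from compound 2 to compound 4 (beyond the scatter), the first step that isolates a single change. This position, on an aromatic carbon next to the ring nitrogen and meta to a large group, therefore responds to substitution in this read-out, even though the exchange leaves the hydrogen-bond acceptor count and the absence of net charge as they were and the rest of the structure untouched. No measurement at hand bears on why the number moves.

The exchange removes the four-membered non-aromatic ring, reduces the group from 4 heavy atoms to 2, and replaces nitrogen with oxygen as the attached atom, so the pair cannot show which of these differences carries the step; dimethylamino or ethoxy on the same carbon would begin to separate them. As far as these compounds go, whether a step of this size holds on another background also stays open, as it rests on this single pair.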